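The compounds below may be only part of what the source reports. "The series", "measured", "known", "first", "only" and "open" are said of these compounds alone.

Compound 3 `O=C(N[C@H](CO)C(=O)NO)c1ccc(C#Cc2ccccc2)cc1` has been measured in a physicochemical assay for lipophilicity (a higher number here means a more lipophilic compound, a lower number a more polar compound), where compound 3 gives 2. Compound 1 `O=C(N[C@@H](CO)C(=O)NO)c1ccc(C#Cc2ccccc2)cc1` gives 2 in this assay, and the step of no change at the digits printed from compound 1 to compound 3 (within the scatter), which rests on (the fact that compounds 1 and 3 differ only in the configuration as drawn), leaves compound 3 level with compound 1. Compound 2 `O=C(NC1(C(=O)NO)CCSCC1)c1ccc(C#Cc2ccccc2)cc1` gives > 3, which is a limit of the assay and not a number, as the limit of > 3 in this assay, at which 1 of the 3 values shown sits, notes. Compound 4 `O=C(NC1(C(=O)NO)CCC1)c1ccc(C#Cc2ccccc2)cc1` is not yet measured. It differs from compound 3 by a group of 8 heavy atoms (5 carbon, 1 nitrogen, 2 oxygen; one four-membered non-aromatic ring of carbon only) in place of a group of 7 heavy atoms (3 carbon, 1 nitrogen, 3 oxygen; no ring), on an amide-type nitrogen. Going by the values given here, the one measured step concerns configuration alone and does not bear on a change of this kind; compound 2, however, also carries a ring on the amide-type nitrogen. The step of a number 0.80 log units higher from compound 3 to compound 4 (beyond the scatter) is therefore expected to run upward, beyond the scatter. Compound 4 is estimated at 2.8, between 2.3 and 3.3.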

Compound 4, distribution coefficient: > 3
Compound 4: no number, only a limit; the forecaster's own chance of this, stated with the estimate: 25%; middle value at least 0.20 log units away from the limit.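

On the amide-type nitrogen, putting 1-(hydroxycarbamoyl)cyclobutyl in place of the ring-free group gives a clear rise in this assay: a number at least 1.00 log units higher from compound 3 to compound 4 (beyond the scatter), and likewise a number at least 1.00 log units higher from compound 1 to compound 4 (beyond the scatter). Going by these compounds alone, the only earlier step at this position concerned configuration and showed no change, so this is the first sign that exchanging the group itself moves the value. Compound 4 gives > 3, which is a limit of the assay and not a number: the limit of > 3 in this assay, at which 2 of the 4 values shown sit.

On these data alone, the true size of the step stays open, as does whether the ring or the lost oxygen accounts for it. As far as these compounds go, how a group carrying an amine at this place would read in this assay also remains open.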